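The source may hold more compounds than are shown below. What is called first, only, known or untested is meant among the compounds shown, and "the series" means these compounds.

Measured so far:
compound 1 `CCCCCCCCCCCCCCC[C@H](O)[C@@H](COP(=O)(O)O)N=[N+]=[N-]`: 6300 nM
compound 2 `CCCCCCCCCCCCC/C=C/[C@H](O)[C@@H](COP(=O)(O)O)N=[N+]=[N-]`: 5600 nM
compound 3 `CCCCCCCCCCCCC/C=C/[C@@H](O)[C@H](COP(=O)(O)O)NCc1c(COP(=O)(O)O)cnc(C)c1O`: "not determined" (no result reported)

In an assay on isolated protein for inhibition of sphingosine-1-phosphate lyase 1 (Homo sapiens), using Lineweaver-Burk analysis (on this read-out lower numbers stand for stronger inhibition and higher numbers for weaker inhibition), compound 2 and compound 1 give numbers within the usual scatter of each other, so the two cannot be ordered. Compound 3 has no number. Compound 4 `CCCCCCCCCCCCC/C=C/[C@@H](O)[C@H](COP(=O)(O)O)N=[N+]=[N-]` is still to be measured. From compound 2 to compound 4 the change is: the two compounds have the same atoms and bonds; at least one stereo element is drawn with a configuration in one of them and without one in the other: 2 of 4 stereo elements differ; a stereocentre at a saturated chain carbon is drawn S in compound 2 and R in compound 4; a stereocentre at a saturated chain carbon is drawn R in compound 2 and S in compound 4. Among the compounds with values here, no step between measured compounds tests such an inversion, so the direction of the step from compound 2 to compound 4 is open. Compound 4 is expected near compound 2, with the step of a 1.4-fold lower number from compound 2 to compound 4 (0.15 log units; within the scatter) given a wide range, at 4000 nM (range 1000 nM to 15000 nM).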

Compound 4, inhibition constant: 9100 nM
Compound 4: the middle estimate sits 2.3-fold (0.36 log units) below what was measured, within the range that was stated.
By their numbers in this assay, from the lowest: compounds 2, 1 and 4 (each within the scatter of the next).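

In this assay, within the data shown here, the paired inversion of the two stereocentres at saturated chain carbons can now be read for the first time, as a 1.6-fold higher number from compound 2 to compound 4 (0.21 log units; within the scatter). With the azide retained, these two drawn configurations therefore cannot be ordered. One caution attaches to this pair: the fact that one of compounds 2 and 4 is drawn with a defined configuration and the other without, at the place where they differ.

Going by these compounds, it remains open whether an amine in place of the azide, or a longer chain, would separate the two configurations. On these data alone, the effect of inverting only one of the two stereocentres also remains open.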